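The source may report more compounds than this note shows. Statements on the series, on what has been measured and on what is new or still open speak of the compounds shown alone.

Measured so far:
compound 1, `CN1C(=O)[C@@]2(c3ccccc31)N(C)C[C@@H](c1ccc(F)cc1)[C@@]21Cc2ccccc2C1=O`: 25.5%
compound 2, `CN1C[C@@H](c2ccc(Cl)cc2)[C@@]2(Cc3ccccc3C2=O)[C@@]12C(=O)Nc1ccccc12`: 15.6%

In a functional assay on the whole organism (strain Wister albino) for inhibition, with Rattus norvegicus as the target, read by paw edema, with stated times of 1 h and 4 h, at a dose of 50 mg/kg by the intraperitoneal route (a lower number here means less inhibition, a higher number more inhibition at the dose given (going by the name of the read-out)), compound 2 stands lowest of the two numbers, though compound 1 sits within the scatter of it, so the two cannot be ordered. Compound 3, `CN1C(=O)[C@@]2(c3ccccc31)N(C)C[C@@H](c1ccc(Cl)cc1)[C@@]21Cc2ccccc2C1=O`, is not yet measured; it differs from compound 2 by methyl in place of hydrogen on an amide-type nitrogen in a ring. For the measured compounds named here, no measured pair shows this change, so nothing measured tells its effect. The step from compound 2 to compound 3 in this assay is expected to be small, a number 5.4 percentage points higher from compound 2 to compound 3 (within the scatter), not beyond the scatter in either direction. Compound 3 is estimated at 21%, between 8% and 34%.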

Compound 3, a percentage reported as inhibition, in the whole organism at one dose (the size of the read-out at that dose, not a potency): 8.5%
For compound 3 the middle estimate is 12.5 percentage points above the measured one; the range from low to high includes it.
By their numbers in this assay, from the lowest: compounds 3, 2 and 1 (each within the scatter of the next, the first and the last beyond it).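

In this assay, methyl in place of hydrogen on the amide-type nitrogen in a ring gives a number 7.1 percentage points lower from compound 2 to compound 3 (within the scatter), so this change shows no effect that can be told from the scatter. Chloro in place of fluoro on an aromatic carbon, with that methyl present in both compounds, gives a number 17 percentage points lower from compound 1 to compound 3 (beyond the scatter), the only step here beyond the scatter. No measurement at hand explains either step. As far as these compounds go, whether bromo or methoxy on that aromatic carbon would extend this modest step remains open, as does whether a longer chain such as ethyl on the nitrogen would leave the number within the scatter.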